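From Chloro to Methylsulfanyl in a Growth Inhibition Series

The source may hold more compounds than are shown below. What is called first, only, known or untested is meant among the compounds shown, and "the series" means these compounds.

- compound 1 `Cc1ccc(S/C(=C/c2sccc2C)C(=O)c2ccc(Br)cc2)cc1` gives 50000 nM
- compound 2 `Cc1ccc(S/C(=C/c2ccc(Cl)c(Cl)c2)C(=O)c2ccc(Br)cc2)cc1` gives 50000 nM
- compound 3 `Cc1ccc(S/C(=C/c2ccc(Cl)cc2)C(=O)c2ccc(Br)cc2)cc1` gives 10000 nM

In a functional assay on DU-145 cells (Homo sapiens) for inhibition, read by trypan blue exclusion, with a stated time of 96 h (on this read-out lower numbers stand for stronger inhibition of growth and higher numbers for weaker inhibition of growth), compound 3 stands lowest of the three at 10000 nM, and its gaps to the other two lie beyond the scatter. Compound 4 `CSc1ccc(/C=C(/Sc2ccc(C)cc2)C(=O)c2ccc(Br)cc2)cc1` has not yet been measured. It differs from compound 3 by one group, (methylsulfanyl in place of chloro on an aromatic carbon), with methylsulfanyl in place of chloro on an aromatic carbon, para to a large group.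

Among the compounds with values here, no measured step makes this exact exchange, so the evidence is indirect. The closest is a 5.0-fold lower number from compound 2 to compound 3 (0.70 log units; beyond the scatter), where hydrogen replaces chloro. Replacing the aromatic group gave a 5.0-fold lower number from compound 1 to compound 3 (0.70 log units; beyond the scatter), while no change at the digits printed from compound 1 to compound 2 (within the scatter) showed no change. Both other aromatic groups tested, in compound 1 and compound 2, gave higher numbers than the 4-chlorophenyl of compound 3, so a slight drift upward is expected, probably not beyond the scatter. The expected step is a 1.5-fold higher number from compound 3 to compound 4 (0.18 log units; within the scatter). For compound 4 the estimated value is 15000 nM, with an expected range from 5000 nM to 50000 nM.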

Compound 4, concentration for 50% growth inhibition: 50000 nM
For compound 4 the middle estimate is 3.3-fold (0.52 log units) below the measured one; the range from low to high includes it.
By their numbers in this assay, from the lowest: compound 3; then compounds 1, 2 and 4 (each within the scatter of the next).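

In this assay, methylsulfanyl in place of chloro on this aromatic carbon, para to a large group, gives a 5.0-fold higher number from compound 3 to compound 4 (0.70 log units; beyond the scatter) and so does not keep the lower number that went with the chloro. The new compound also falls in with the other two, with no change at the digits printed from compound 2 to compound 4 (within the scatter) and no change at the digits printed from compound 1 to compound 4 (within the scatter) in the same assay. Among the four compounds, the 4-chlorophenyl of compound 3 therefore stands alone at the low end, and 4-(methylsulfanyl)phenyl, 3,4-dichlorophenyl and 3-methylthiophen-2-yl cannot be told apart by their numbers.

Nothing shown here explains why the exchange of chloro for methylsulfanyl raises the number. Going by these compounds, whether a fluoro, a methoxy or an amine at this place would stay with compound 3 or join the other three remains open.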